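Rearranged Purine Group on a Protected Bicyclic Nucleoside

The source may report more compounds than this note shows. Statements on the series, on what has been measured and on what is new or still open speak of the compounds shown alone.

Compound 1 `CC(C)(C)[Si](C)(C)OC[C@H]1O[C@@H](n2cnc3c(N)ncnc32)[C@H](O[Si](C)(C)C(C)(C)C)[C@@]12OS(=O)(=O)C=C2N`: 7300 nM
Compound 2 `COc1ncnc2c1ncn2[C@@H]1O[C@H](CO[Si](C)(C)C(C)(C)C)[C@@]2(OS(=O)(=O)C=C2N)[C@H]1O[Si](C)(C)C(C)(C)C`: 21000 nM
Compound 3 `CC(C)(C)[Si](C)(C)OC[C@H]1O[C@@H](n2cnc3ncn([C@@H]4O[C@H](CO[Si](C)(C)C(C)(C)C)[C@@]5(OS(=O)(=O)C=C5N)[C@H]4O[Si](C)(C)C(C)(C)C)c3c2=O)[C@H](O[Si](C)(C)C(C)(C)C)[C@]12OS(=O)(=O)C=C2N`: > 150000 nM, a limit

In a functional assay on MT4 cells (Homo sapiens) for cytotoxicity (a lower number here means that less compound is tolerated, a higher number that more compound is tolerated), compound 2 gives 21000 nM, the highest of the two plain numbers. Its nearest neighbour is compound 1, which in this assay gives 7300 nM, a gap beyond the scatter. Compound 3 yields only a limit, > 150000 nM. That is the limit of > 150000 nM in this assay, at which 1 of the 3 values shown sits.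

Compound 4 `Cn1cnc2ncn([C@@H]3O[C@H](CO[Si](C)(C)C(C)(C)C)[C@@]4(OS(=O)(=O)C=C4N)[C@H]3O[Si](C)(C)C(C)(C)C)c2c1=O` differs from compound 2 by a group of 11 heavy atoms (6 carbon, 4 nitrogen, 1 oxygen; one five-membered aromatic ring with 2 hetero atoms, one six-membered aromatic ring with 2 hetero atoms) in place of a group of 11 heavy atoms (6 carbon, 4 nitrogen, 1 oxygen; one five-membered aromatic ring with 2 hetero atoms, one six-membered aromatic ring with 2 hetero atoms), on a saturated ring carbon; the two have the same atoms, joined differently. For the measured compounds named here, no pair of measured compounds shows a change of this kind, so the size of the step is not anchored by any measured comparison. With compound 2 and compound 1 lying within a modest span and the change leaving the protected sugar core untouched, the author expects the step from compound 2 to compound 4, a 1.0-fold higher number from compound 2 to compound 4 (0.02 log units; within the scatter), to fall within the scatter, in no fixed direction. Compound 4 is therefore estimated at 22000 nM, with a range from 8000 nM to 70000 nM in this assay.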

Compound 4, half-maximal cytotoxic concentration: 156000 nM
Estimate against measurement, compound 4: 7.1-fold (0.85 log units) below, outside the stated range (above it).
By their numbers in this assay, from the lowest: compound 1; then compound 2; then compound 4.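

Exchanging one group for another made of the same atoms, joined differently and now with a double bond outside aromatic rings, on the saturated ring carbon next to the ring oxygen is not a silent change in this assay: it gives a 7.4-fold higher number from compound 2 to compound 4 (0.87 log units; beyond the scatter). For the compounds shown here, at this position, then, how the atoms of the group are joined can alone move the tolerated concentration, something the earlier compounds, with no step between them, could not show. Compound 3 gives only a limit, which offers no cause for the step: the limit of > 150000 nM in this assay, at which 1 of the 4 values shown sits.

As far as these compounds go, whether the step would hold with an amine or a longer alkyl chain on the entering group remains open. The compounds shown also leave open why the two arrangements differ, and whether the same exchange would do the same on another core.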